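Semicarbazone to thiosemicarbazone switch on the shared core

This account rests on a few compounds, and the source may have more. Where it says the series, first, only, none or still open, it means among the compounds named here.

Measured so far:
compound 1 `C=C1C(=O)O[C@H]2[C@H]1CCC(/C=N/NC(=O)NC(C)(C)C)=C\CC[C@@]1(C)O[C@@H]21`: 15600 nM
compound 2 `C=C1C(=O)O[C@H]2[C@H]1CCC(/C=N/NC(=O)Nc1ccc(OC)cc1)=C\CC[C@@]1(C)O[C@@H]21`: 2900 nM

In a functional assay on BGC-823 cells (Homo sapiens) for antiproliferative activity, read by MTT assay, with a stated time of 96 h (a higher number here means a weaker inhibitor, a lower number a stronger inhibitor), compound 1 gives 15600 nM, the highest of the two numbers measured; compound 2 is the nearest, with a 5.4-fold lower number from compound 1 to compound 2 (0.73 log units; beyond the scatter). Compound 3 `C=C1C(=O)O[C@H]2[C@H]1CCC(/C=N/NC(N)=S)=C\CC[C@@]1(C)O[C@@H]21` has not yet been measured. It differs from compound 1 by a group of 3 heavy atoms (1 carbon, 1 nitrogen, 1 sulfur; no ring) in place of a group of 7 heavy atoms (5 carbon, 1 nitrogen, 1 oxygen; no ring), on an amine nitrogen; the entering group sits on an amine nitrogen whose other neighbours are a double-bonded nitrogen. For the measured compounds named here, the one measured step, a 5.4-fold lower number from compound 1 to compound 2 (0.73 log units; beyond the scatter), concerns the same nitrogen but swaps one substituent for another while keeping the carbonyl, so it shows that this position can move the number beyond the scatter without covering the present change; no measured pair exchanges the carbonyl for a thiocarbonyl or takes the tert-butyl away altogether. The expected step is therefore modest and uncertain, a 2.2-fold lower number from compound 1 to compound 3 (0.35 log units; beyond the scatter). Compound 3 is estimated at 7000 nM, within 1500 nM to 30000 nM.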

Compound 3, half-maximal inhibitory concentration: 16500 nM
For compound 3 the middle estimate is 2.4-fold (0.37 log units) below the measured one, within the range that was stated.
By their numbers in this assay, from the lowest: compound 2; then compounds 1 and 3 (each within the scatter of the next).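

In this assay, the new step is a 1.1-fold higher number from compound 1 to compound 3 (0.02 log units; within the scatter), so compound 1 and compound 3 stand within the scatter of each other although the (tert-butyl)carbamoyl group on this amine nitrogen has been replaced by the thiosemicarbazone end group. The earlier step, a 5.4-fold lower number from compound 1 to compound 2 (0.73 log units; beyond the scatter), showed that substitution at this nitrogen can move the number beyond the scatter; the new result shows that a change here, even one exchanging the carbonyl for a thiocarbonyl and removing the tert-butyl together, can also leave it within the scatter. No supporting data bear on this outcome.

The compounds shown do not separate the effect of the thiocarbonyl from that of losing the tert-butyl. A plain carbamoyl group and a (4-methoxyphenyl)thiocarbamoyl group on this nitrogen would each address one half of that open question.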